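The source may report more compounds than this note shows. Statements on the series, on what has been measured and on what is new or still open speak of the compounds shown alone.

Compound 1 `COc1cc(OC)c(/C=C/S(=O)(=O)Cc2ccc([N+](=O)[O-])cc2)c(OC)c1` and compound 2 `COc1cc(OC)c(/C=C/S(=O)(=O)Cc2ccc(C(=O)O)cc2)c(OC)c1` share a core in which the substituted phenyl sits on the benzyl side of the vinyl sulfone; compound 3 `COc1ccc(CS(=O)(=O)/C=C/c2ccc(F)cc2)cc1` carries a single methoxy on the benzyl ring and its substituent on the styryl ring. In a functional assay on DU-145 cells (Homo sapiens) for antiproliferative activity, read by trypan blue exclusion (a lower number here means a stronger inhibitor, a higher number a weaker inhibitor), compound 1 gives 15000 nM, compound 2 gives 10000 nM and compound 3 gives 1250 nM. Compound 3 therefore stands at the lowest of the three numbers, and its gaps to compound 2 and to compound 1 both lie beyond the scatter. Among the measured compounds shown here, the one step measured, a 1.5-fold lower number from compound 1 to compound 2 (0.18 log units; within the scatter), is the change of the benzyl-ring substituent and stays within the scatter.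

Compound 4 `COc1ccc(CS(=O)(=O)/C=C/c2ccc([N+](=O)[O-])cc2)cc1` differs from compound 3 in one place: nitro in place of fluoro on an aromatic carbon. For the measured compounds named here, no measured pair carries exactly this exchange on the styryl ring; the only guide is that the swap between nitro and carboxy on the other ring, from compound 1 to compound 2, moved the number little. On that basis a step of no more than modest size is expected for compound 4, leaning towards a slightly higher number, a 1.6-fold higher number from compound 3 to compound 4 (0.20 log units; within the scatter). The estimate for compound 4 in this assay is 2000 nM, with a range from 700 nM to 6000 nM.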

Compound 4, half-maximal inhibitory concentration: 7500 nM
For compound 4 the middle estimate is 3.8-fold (0.57 log units) below the measured one; the whole stated range lies below it.
By their numbers in this assay, from the lowest: compound 3; then compounds 4, 2 and 1 (each within the scatter of the next).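

Among the compounds shown here, the exchange of fluoro for nitro on an aromatic carbon of a six-membered aromatic ring of carbon only, para to a large group, is not a neutral one: in this assay the result is a 6.0-fold higher number from compound 3 to compound 4 (0.78 log units; beyond the scatter) and this is the first step to lie beyond the scatter. For the compounds shown here, the only earlier step, a 1.5-fold lower number from compound 1 to compound 2 (0.18 log units; within the scatter) in the same assay, involves a different exchange in a different core and stays within the scatter, so its small size does not carry over to this position. The compounds shown offer no measurement that accounts for the size of the new step.

From the compounds shown here alone, it remains open whether the higher number belongs to nitro specifically or would also appear with an amine, a nitrile or a longer alkyl chain at this position, and whether the parent ring bearing only hydrogen there would sit nearer compound 3 or compound 4. Also open, going by these compounds, is whether the same exchange of fluoro for nitro would give a step of similar size on the core of compound 1, which carries three methoxy groups.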